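A few compounds are considered here, and "the series" means these few. Any claim that something is new, unique, unknown or untested is made for them only; others in the source may bear on it.

Measured so far in a functional assay on HeLa cells (Homo sapiens) for cytotoxicity, read by MTT assay, with a stated time of 48 h; a higher number here means a weaker inhibitor, a lower number a stronger inhibitor:
- compound 1 `COc1ccc(-c2nc3ccccn3c2C(=O)/C=C\Nc2cc(OC)cc(OC)c2)cc1`: 4570 nM
- compound 2 `COc1ccc(-c2nc3ccccn3c2C(=O)/C=C\Nc2ccc3[nH]ccc3c2)cc1`: 13600 nM

Compound 2 has the higher of these two numbers, meaning it is the weaker of the two at killing the cells; the step is a 3.0-fold higher number from compound 1 to compound 2 (0.47 log units; beyond the scatter), a change made at the amine nitrogen.

Compound 3 `O=C(/C=C\Nc1ccc2[nH]ccc2c1)c1c(-c2ccc(Cl)cc2)nc2ccccn12` differs from compound 2 elsewhere: chloro in place of methoxy on an aromatic carbon. Within the data shown here, no measured pair varies this part of the molecule. Among the measured compounds shown here, the one step available, from compound 1 to compound 2, concerns a different position and cannot say how a change on this ring behaves. With nothing to lean on, the expected step in this assay is no change at the digits printed from compound 2 to compound 3 (within the scatter), that is, none beyond the usual scatter, in either direction. The estimate for compound 3 is therefore 13600 nM, expected to fall between 5000 nM and 37000 nM.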

Compound 3, half-maximal inhibitory concentration: 3240 nM
Estimate against measurement, compound 3: 4.2-fold (0.62 log units) above; measured number below the stated range.
By their numbers in this assay, from the lowest: compounds 3 and 1 (each within the scatter of the next); then compound 2.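

Moving from 4-methoxyphenyl to 4-chlorophenyl in this assay gives a 4.2-fold lower number from compound 2 to compound 3 (0.62 log units; beyond the scatter) and so makes compound 3 the stronger of this pair. This shows that the number responds to a change on this ring, not only to the change at the amine nitrogen seen earlier. No measurement at hand explains why this swap has this effect.

On these data alone, whether the step comes from adding chloro or from losing methoxy stays open, as does how a hydrogen, fluoro, trifluoromethyl or an amine would behave at this place. A single pair also cannot say whether the same swap would have a similar effect with the 3,5-dimethoxyphenyl group of compound 1 on the amine nitrogen.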